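A few compounds are considered here, and "the series" means these few. Any claim that something is new, unique, unknown or untested is made for them only; others in the source may bear on it.

Measured in an ADME assay on microsomes from liver (Mus musculus) for metabolic stability, read by LC-MS, using NADPH, with a stated time of 30 min, tested at 0.1 uM; on this read-out lower numbers stand for a less stable compound and higher numbers for a more stable compound:
- compound 1 `O=S(=O)(c1cccc(-c2ccc3nccc(-c4ccncc4)c3n2)c1)N1CCC(O)CC1`: 7%
- compound 2 `CS(=O)(=O)Nc1cccc(-c2ccc3nccc(-c4ccncc4)c3n2)c1`: 50%

Compound 2, at 50%, holds the higher of the two numbers, and the gap to compound 1 lies beyond the scatter. Compound 3 `O=S(=O)(c1cccc(-c2ccc3nccc(-c4ccncc4)c3n2)c1)N1CC[C@H](O)C1` differs from it as follows: (3-hydroxypyrrolidin-1-yl)sulfonyl in place of methanesulfonamido on an aromatic carbon. This puts (3-hydroxypyrrolidin-1-yl)sulfonyl in place of methanesulfonamido on an aromatic carbon. Among the compounds with values here, the one measured step that bears on this is a number 43 percentage points higher from compound 1 to compound 2 (beyond the scatter), a large step that replaced (4-hydroxypiperidin-1-yl)sulfonyl with methanesulfonamido. In this assay a large fall is therefore expected, an estimated a number 36 percentage points lower from compound 2 to compound 3 (beyond the scatter). Compound 3 is expected at 14%, within an estimated range of 3% to 32%.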

Compound 3, percent of the compound remaining: 12%
Estimate against measurement, compound 3: 2 percentage points above; measured number inside the range.
By their numbers in this assay, from the lowest: compounds 1 and 3 (each within the scatter of the next); then compound 2.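

In this assay, a second hydroxylated ring on the sulfonyl gives a large loss against the methanesulfonamido group, a number 38 percentage points lower from compound 2 to compound 3 (beyond the scatter). Ring size on the sulfonyl sulfur makes no distinction here: with 3-hydroxypyrrolidin-1-yl in place of 4-hydroxypiperidin-1-yl, the step is a number 5 percentage points higher from compound 1 to compound 3 (within the scatter). No available evidence explains either step. Still open, on these data alone, is whether a morpholin-4-ylsulfonyl group, which has no hydroxyl, would share the low numbers of compound 1 and compound 3. Also open, as far as these compounds go, is whether an ethanesulfonamido group would stay close to compound 2.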